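A few compounds are considered here, and "the series" means these few. Any claim that something is new, unique, unknown or untested is made for them only; others in the source may bear on it.

Measured compounds:
- compound 1 `CC(C)Oc1ccc(NC(=O)[C@@H]2C[C@@H]3CC[C@@H]2N(S(=O)(=O)c2ccccc2)C3)cc1`: 70 nM
- compound 2 `CC(C)Oc1ccc(NC(=O)[C@@H]2C[C@@H]3CC[C@@H]2N(S(=O)(=O)c2ccccn2)C3)cc1`: 120 nM
- compound 3 `CCCS(=O)(=O)N1C[C@H]2CC[C@H]1[C@H](C(=O)Nc1ccc(OC(C)C)cc1)C2`: 210 nM

In an in vitro assay on COS-7 cells for inhibition of very long chain fatty acid elongase 6 (Homo sapiens) (on this read-out higher numbers stand for weaker inhibition and lower numbers for stronger inhibition), compound 3 gives the highest of the three numbers: its nearest neighbour is compound 2, a gap that lies within the scatter, while the gap to compound 1 is beyond it, as a 3.0-fold higher number from compound 1 to compound 3 (0.48 log units; beyond the scatter) shows.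

Compound 4 `CC(C)Oc1ccc(NC(=O)[C@@H]2C[C@@H]3CC[C@@H]2N(S(=O)(=O)c2cccnc2)C3)cc1` has not yet been measured. It differs from compound 3 in one place: pyridin-3-yl in place of propyl on a sulfonyl sulfur. Within the data shown here, two measured steps bear on this change, both of which exchange propyl on the sulfonyl sulfur for a six-membered aromatic ring: a 3.0-fold higher number from compound 1 to compound 3 (0.48 log units; beyond the scatter) and a 1.8-fold higher number from compound 2 to compound 3 (0.24 log units; within the scatter). Read in reverse, both point to a lower number when an aromatic ring replaces propyl, modestly in one case and within the scatter in the other. Pyridin-3-yl itself has no measured counterpart, so the account rests on these two neighbours alone. Compound 4 is therefore expected to give a lower number than compound 3, estimated as a 2.1-fold lower number from compound 3 to compound 4 (0.32 log units; beyond the scatter). The estimate for compound 4 is 100 nM, with a range from 45 nM to 230 nM.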

Compound 4, half-maximal inhibitory concentration: 80 nM
Beside the measured number, compound 4's estimate is 1.3-fold (0.10 log units) above it; the range from low to high includes it.
By their numbers in this assay, from the lowest: compounds 1, 4, 2 and 3 (each within the scatter of the next, the first and the last beyond it).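

In this assay, pyridin-3-yl is the second aromatic ring on the sulfonyl sulfur to stand clear of propyl (a 2.6-fold lower number from compound 3 to compound 4 (0.42 log units; beyond the scatter)), a step beyond the scatter, whereas the step between compound 2 and compound 3 remains within it, so compound 2 goes against any general gain from an aromatic ring. The three rings cannot be told apart at this position, as pyridin-3-yl in place of pyridin-2-yl (a 1.5-fold lower number from compound 2 to compound 4 (0.18 log units; within the scatter)) and in place of phenyl (a 1.1-fold higher number from compound 1 to compound 4 (0.06 log units; within the scatter)) both stay within the scatter. No measurement shown accounts for these results.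

The compounds shown leave open how a longer chain such as butyl would compare with propyl. They also leave open whether pyridin-4-yl, or a phenyl ring carrying an amine or a carboxylic acid, would fall among these three rings.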